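Trading trifluoromethyl for tert-butyl on the aromatic ring

A few compounds are considered here, and "the series" means these few. Any claim that something is new, unique, unknown or untested is made for them only; others in the source may bear on it.

In a functional assay on A549 cells (Homo sapiens) for inhibition (a lower number here means a stronger inhibitor, a higher number a weaker inhibitor), compound 1 (`O=C1C=CC(OCC(F)(F)F)N1c1ccc(C(F)(F)F)cc1`) gives 8390 nM, and compound 2 (`Cc1ccc(N2C(=O)C=CC2OCC(F)(F)F)cc1`) gives 13700 nM, so the two lie within the scatter of each other. Compound 3 (`CC(C)(C)c1ccc(N2C(=O)C=CC2OCC(F)(F)F)cc1`) keeps the core of compound 1 and alters one group: tert-butyl in place of trifluoromethyl on an aromatic carbon. Among the measured compounds shown here, the only measured guide replaces the same trifluoromethyl with methyl: a 1.6-fold higher number from compound 1 to compound 2 (0.21 log units; within the scatter). One step is thin evidence, but it gives no reason to expect a shift beyond the scatter in this assay. The estimated step is a 1.3-fold higher number from compound 1 to compound 3 (0.12 log units; within the scatter). Compound 3 is therefore expected at 11000 nM, within an estimated range of 5000 nM to 25000 nM.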

Compound 3, half-maximal inhibitory concentration: 8500 nM
The estimate for compound 3 lay 1.3-fold (0.11 log units) above the measured number; the measured number falls inside the stated range.
By their numbers in this assay, from the lowest: compounds 1, 3 and 2 (each within the scatter of the next).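

In this assay, the step of a 1.0-fold higher number from compound 1 to compound 3 (0.01 log units; within the scatter) and the step of a 1.6-fold lower number from compound 2 to compound 3 (0.21 log units; within the scatter) show that tert-butyl on this aromatic carbon cannot be told apart from trifluoromethyl or methyl. Across these three groups, the number at this position therefore stays within the scatter, even when four carbon atoms replace one carbon and three fluorine atoms. Nothing available explains why these numbers stay together.

Going by these compounds, whether an amine or a carboxylic acid at this position would move the number beyond the scatter remains open. So does whether any change to the trifluoroethoxy side of the shared core would do so.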